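Swapping a Fluorinated Ring for a Phenoxy Tail

A few compounds are considered here, and "the series" means these few. Any claim that something is new, unique, unknown or untested is made for them only; others in the source may bear on it.

Compound 1 `O=C(O)CCCc1cn(CC(=O)O)c2c(/C=C/c3ccc(OCCCCc4c(F)ccc(F)c4F)cc3)cccc12` and compound 2 `O=C(O)CCCn1cc(CC(=O)O)c2c(/C=C/c3ccc(OCCCCOc4ccccc4)cc3)cccc21` were studied in a physicochemical assay for permeability, using PAMPA, with a stated time of 4 h, at pH 6.2, tested at 50 uM; a lower number here means that the compound crosses the layer more slowly, a higher number that the compound crosses the layer faster. In this assay compound 1 gives 1.4 10^-6 cm/s, the lower of the two numbers, while compound 2 gives 6.9 10^-6 cm/s. Compound 3 `O=C(O)CCCc1cn(CC(=O)O)c2c(/C=C/c3ccc(OCCCCOc4ccccc4)cc3)cccc12` has not yet been measured. It keeps the shared core of compound 1 but carries phenoxy in place of 2,3,6-trifluorophenyl on a saturated chain carbon, four bonds along the chain from an oxygen on an aromatic ring. Among the compounds with values here, no measured pair shows this exact change, so its size is uncertain; compound 3 is expected to move upward, with an estimated step of a 2.5-fold higher number from compound 1 to compound 3 (0.40 log units; beyond the scatter). Compound 3 is therefore estimated at 3.5 10^-6 cm/s, within a range from 1.5 10^-6 cm/s to 8 10^-6 cm/s.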

Compound 3, apparent permeability: 1.6 10^-6 cm/s
For compound 3 the middle estimate is 2.2-fold (0.34 log units) above the measured one; low and high end bracket the measured number.
By their numbers in this assay, from the lowest: compounds 1 and 3 (each within the scatter of the next); then compound 2.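

In this assay putting phenoxy in place of 2,3,6-trifluorophenyl on this saturated chain carbon brings a 1.1-fold higher number from compound 1 to compound 3 (0.06 log units; within the scatter) and so does not separate the two compounds. At this position, a tail ending in phenoxy and one ending in 2,3,6-trifluorophenyl therefore read alike, although the groups differ in their atoms. No measurement available here explains this result. Still open, going by these compounds, is whether an amine or a carboxylic acid at this position, or a longer chain leading to it, would move the number.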